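The source may report more compounds than this note shows. Statements on the series, on what has been measured and on what is new or still open speak of the compounds shown alone.

Measured so far in a functional assay on Huh-7 cells (Homo sapiens) for antiproliferative activity, read by sulforhodamine B assay, with a stated time of 72 h; a higher number here means a weaker inhibitor, a lower number a stronger inhibitor:
compound 1 `Cc1ccccc1COc1ccc(-c2cc(CN3CCN(Cc4ccc(C(F)(F)F)cc4)CC3)no2)cc1` gives 1200 nM
compound 2 `Fc1ccccc1COc1ccc(-c2cc(CN3CCN(Cc4ccc(C(F)(F)F)cc4)CC3)no2)cc1` gives 1500 nM
compound 3 `COc1cc(COc2ccc(-c3cc(CN4CCN(Cc5ccc(C(F)(F)F)cc5)CC4)no3)cc2)cc(OC)c1` gives 1500 nM

For the measured compounds named here, compound 3 stands level with compound 2 at the digits recorded, the two together the highest numbers of the three; its only other neighbour is compound 1, and that step, a 1.3-fold higher number from compound 1 to compound 3 (0.10 log units; within the scatter), is within the scatter, as are a 1.3-fold higher number from compound 1 to compound 2 (0.10 log units; within the scatter) and no change at the digits printed from compound 2 to compound 3 (within the scatter). Across these three the whole series sits in one band in this assay.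

Compound 4 `COc1cc(COc2ccc(-c3cc(CN4CCN(Cc5ccc(C(F)(F)F)cc5)CC4)no3)cc2)cc(OC)c1OC` differs from compound 3 by methoxy in place of hydrogen on an aromatic carbon. Going by the values given here, no measured step adds a group to this phenyl in the way the change does; the nearest comparisons are the two exchanges of the whole phenyl on the saturated chain carbon bound to the oxygen, a 1.3-fold higher number from compound 1 to compound 3 (0.10 log units; within the scatter) and no change at the digits printed from compound 2 to compound 3 (within the scatter), both within the scatter. Among the compounds with values here, nothing among the measured compounds therefore points to a move beyond the scatter in this assay, in either direction. The expected step is no change at the digits printed from compound 3 to compound 4 (within the scatter). For compound 4 the estimate in this assay is 1500 nM, with a range from 700 nM to 3500 nM.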

Compound 4, half-maximal inhibitory concentration: 500 nM
Compound 4: the middle estimate sits 3.0-fold (0.48 log units) above what was measured, outside the stated range (below it).
By their numbers in this assay, from the lowest: compound 4; then compounds 1, 2 and 3 (each within the scatter of the next).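

Adding methoxy to an aromatic carbon ortho to two methoxy groups and para to a large group produces the first change in the series to leave the scatter in this assay, with a 3.0-fold lower number from compound 3 to compound 4 (0.48 log units; beyond the scatter). The 3,4,5-trimethoxyphenyl group also separates compound 4 from the other two compounds, with a 3.0-fold lower number from compound 2 to compound 4 (0.48 log units; beyond the scatter) and a 2.4-fold lower number from compound 1 to compound 4 (0.38 log units; beyond the scatter), so compound 4 is the strongest of the four, whereas the 3,5-dimethoxyphenyl group of compound 3 did not stand apart from the 2-fluorophenyl or 2-methylphenyl groups. No measurement shown accounts for this step.

On these data alone, it remains open whether a hydroxyl or ethoxy group on the same carbon would give a similar step. As far as these compounds go, it also remains open whether methoxy there needs the two methoxy groups ortho to it.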